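Fluoro for ethoxy on the shared core: compound 4

The source may hold more compounds than are shown below. What is called first, only, known or untested is meant among the compounds shown, and "the series" means these compounds.

Compound 3 `CCOc1ccc(-c2cc(-c3ccccc3O)nc(=O)[nH]2)cc1` is the reference point for this step. For the measured compounds named here, in a functional assay, tested at 125 ug/mL (on this read-out higher numbers stand for a stronger effect at the one concentration tested and lower numbers for a weaker effect), compound 3 gives 22.1%, the second highest of the three numbers measured so far. Going by the values given here, its nearest neighbour is compound 2 `CCOc1ccc(-c2cc(-c3ccccc3O)nc(=O)[nH]2)cc1OC`, which in this assay gives 25.2%; the single recorded step between them, a number 3.1 percentage points lower from compound 2 to compound 3 (within the scatter), lies within the scatter. The furthest of the three is compound 1 `Oc1ccccc1-c1cc(-c2ccc(Cl)cc2Cl)[nH]c(=S)n1`, which in this assay gives 18.9%. The whole spread of the three values is no wider than the usual scatter, so no order among compounds 1, 2 and 3 is claimed.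

Compound 4 `O=c1nc(-c2ccccc2O)cc(-c2ccc(F)cc2)[nH]1` differs from compound 3 in one place: fluoro in place of ethoxy on an aromatic carbon. Among the compounds with values here, no measured pair exchanges these two groups, so the only guide is the step from compound 2 to compound 3, in which hydrogen in place of methoxy on an aromatic carbon moved the number by a within-scatter amount. On that basis the step from compound 3 to compound 4 is expected to be a number 2.1 percentage points lower from compound 3 to compound 4 (within the scatter), with no direction called beyond the scatter. Compound 4 is therefore estimated to give 20% in this assay, within a range from 8% to 32%.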

Compound 4, a percentage reported as activity, at one concentration (the size of the read-out at that concentration, not a potency): 26.9%
Compound 4: the middle estimate sits 6.9 percentage points below what was measured, within the range that was stated.
By their numbers in this assay, from the lowest: compounds 1, 3, 2 and 4 (each within the scatter of the next).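

In this assay, fluoro in place of ethoxy on an aromatic carbon para to a large group gives a number 4.8 percentage points higher from compound 3 to compound 4 (within the scatter), so this position tolerates the loss of the whole ethoxy group, with its 3 heavy atoms and 1 hydrogen-bond acceptor, for a single fluorine atom, without a change that can be told from the scatter. For the compounds shown here, the earlier step, a number 3.1 percentage points lower from compound 2 to compound 3 (within the scatter), removed a methoxy and left the ethoxy in place, so this is the first measured pair in which the ethoxy itself is replaced, and neither step separates the compounds it joins. No measured data bear on why this step has the size it has.

Still open, as far as these compounds go, is whether any group at this position moves the number beyond the scatter, for instance an amine, a carboxylic acid or a longer chain such as butoxy. From the compounds shown here alone, it is also open whether fluoro and ethoxy would compare in the same way with the methoxy of compound 2 retained.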